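Lengthening the side chain of a carbamate series

The source may report more compounds than this note shows. Statements on the series, on what has been measured and on what is new or still open speak of the compounds shown alone.

Compound 1 `COc1ccc(NC(=O)Oc2cc(=O)n(CCCO)c3c2CC(CC=C(C)C)C(C)(C)C3)cc1`: 0%
Compound 2 `COc1ccccc1NC(=O)Oc1cc(=O)n(CCCO)c2c1CC(CC=C(C)C)C(C)(C)C2`: 0%
Compound 3 `CC(C)=CCC1Cc2c(OC(=O)Nc3ccccc3F)cc(=O)n(CCCO)c2CC1(C)C`: 0%

In a functional assay on PANC-1 cells (Homo sapiens) for inhibition, read by MTT assay, with a stated time of 24 h, tested at 10 uM (on this read-out higher numbers stand for more inhibition at the one concentration tested (going by the name of the read-out) and lower numbers for less inhibition), compound 2 gives 0%, level with compound 1 and compound 3 at the digits shown; the step of no change at the digits printed from compound 1 to compound 2 (within the scatter) and the step of no change at the digits printed from compound 2 to compound 3 (within the scatter) both lie within the scatter, as does no change at the digits printed from compound 1 to compound 3 (within the scatter). Compound 4 `COc1ccccc1NC(=O)Oc1cc(=O)n(CCCO)c2c1CC(C/C=C(\C)CCC=C(C)C)C(C)(C)C2` keeps the 2-methoxyphenyl carbamate of compound 2 and differs in one place only: 3-methylbut-2-en-1-yl in place of hydrogen on a saturated chain carbon bound to a double-bonded chain carbon. For the measured compounds named here, none of the measured steps touches this place; all three concern the phenyl on the amide-type nitrogen, and all were flat. Nothing measured therefore speaks for a move beyond the scatter, and the shared level of compounds 1 to 3 offers no higher number to build on. Compound 4 is expected to give 2% (range -8% to 15%), an expected step of a number 2 percentage points higher from compound 2 to compound 4 (within the scatter) that stays within the scatter.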

Compound 4, a percentage reported as inhibition, at one concentration (the size of the read-out at that concentration, not a potency): 0%
Beside the measured number, compound 4's estimate is 2 percentage points above it, within the range that was stated.
By their numbers in this assay, from the lowest: compounds 1, 2, 3 and 4 (each within the scatter of the next).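

The earlier compounds shown here varied only the phenyl on the amide-type nitrogen, whereas compound 4 changes the side chain, and in this assay this gives no change at the digits printed from compound 2 to compound 4 (within the scatter). Going from 3-methylbut-2-en-1-yl to 3,7-dimethylocta-2,6-dien-1-yl thus leaves the read-out as flat as the phenyl changes did. Nothing available explains this result.

From the compounds shown here alone, whether an amine or a carboxylic acid at the end of this chain would move the number stays open. So does whether replacing the chain on the other ring nitrogen, which carries the hydroxyl, would.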